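Cyano for Chloro on a Rearranged Core

The compounds below may be only part of what the source reports. "The series", "measured", "known", "first", "only" and "open" are said of these compounds alone.

Compound 1, `CCOc1nc(Cl)cc(NC(=O)NCc2cc(C)c(-c3cn(C)nc3C(F)(F)F)nn2)c1C`, is the reference point of this small set. In a functional assay on HFL1 cells for antagonist activity at sphingosine 1-phosphate receptor 2 (Homo sapiens), read by ELISA, with a stated time of 24 h, in the absence of a further agent (a higher number here means a weaker inhibitor, a lower number a stronger inhibitor), compound 1 gives 15 nM. Compound 2, `CCOc1nc(C#N)cc(NC(=O)NCc2cc(C)c(-c3cn(C)nc3C(F)(F)F)nn2)c1C`, carries a (cyano in place of chloro on an aromatic carbon), and in this assay compound 2 gives 24 nM, so that a 1.6-fold higher number from compound 1 to compound 2 (0.20 log units; within the scatter). Compound 3, `CCOc1nc(C)cc(NC(=O)NCc2cc(C)c(-c3cn(C)nc3C(F)(F)F)nn2)c1Cl`, keeps the same atoms as compound 1 but joined differently, with a (3-chloro-2-ethoxy-6-methylpyridin-4-yl in place of 6-chloro-2-ethoxy-3-methylpyridin-4-yl on an amide-type nitrogen), and in this assay compound 3 gives 26 nM, so that a 1.7-fold higher number from compound 1 to compound 3 (0.24 log units; within the scatter). Compound 2 and compound 3 sit within the scatter of each other.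

Compound 4, `CCOc1nc(C)cc(NC(=O)NCc2cc(C)c(-c3cn(C)nc3C(F)(F)F)nn2)c1C#N`, has not yet been measured. It is made from compound 3 by a (cyano in place of chloro on an aromatic carbon). Among the measured compounds shown here, this is the same kind of change as the one from compound 1 to compound 2, but not the same: in compound 2 the cyano stands next to the ring nitrogen, meta to a large group and meta to an ethoxy group, whereas in compound 4 it stands two atoms from the ring nitrogen, ortho to a large group and ortho to an ethoxy group.

The step from compound 3 to compound 4 in this assay is expected to be a 1.5-fold higher number from compound 3 to compound 4 (0.16 log units; within the scatter), a small one, resting on the earlier step of a 1.6-fold higher number from compound 1 to compound 2 (0.20 log units; within the scatter), with added uncertainty because the place of the change differs. Compound 4 is therefore estimated to give 38 nM in this assay, expected to lie between 15 nM and 95 nM.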

Compound 4, half-maximal inhibitory concentration: > 20000 nM
Compound 4 was reported as a limit; the forecaster's own chance of this, stated with the estimate: 3%; middle value at least 520-fold (2.72 log units) from the limit.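

In this assay, cyano in place of chloro on the core of compound 3 gives an at least 760-fold higher number from compound 3 to compound 4 (2.88 log units; beyond the scatter), so this change does not carry over from one core to the other in this series: the same change on two cores in this assay, a 1.6-fold higher number (0.20 log units; within the scatter) from compound 1 to compound 2 and an at least 760-fold higher number (2.88 log units; beyond the scatter) from compound 3 to compound 4, at least 480-fold (2.68 log units) apart, beyond the scatter of two such steps

Compound 4 gives > 20000 nM, which is a limit of the assay and not a number, so the full size of its step remains unknown: the limit of > 20000 nM in this assay, at which 1 of the 4 values shown sits.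

Among the compounds shown here, with only one pair on each core, the result shows that the outcome of this change depends on the core, but it does not show why, nor whether a cyano ortho to an ethoxy group would behave the same way on any other core.

The compounds shown leave open whether a fluoro, a bromo or an amine in the place of the chloro of compound 3 would stay close to it in this assay, or whether only the cyano behaves in this way. They also leave open whether a longer chain in place of the ethoxy group would alter the outcome of the cyano change at this place.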